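The source may hold more compounds than are shown below. What is called first, only, known or untested is meant among the compounds shown, and "the series" means these compounds.

In a functional assay on MCF7 cells (Homo sapiens) for antiproliferative activity, read by MTT assay, with a stated time of 48 h (on this read-out higher numbers stand for weaker inhibition and lower numbers for stronger inhibition), compound 1 `CC(=O)N1N=C(c2ccc3ccccc3c2)OC1c1ccccc1` gives 2.43 ug/mL and compound 2 `CC(=O)N1N=C(c2ccc3ccccc3c2)OC1c1ccccc1Cl` gives 2.36 ug/mL, and between them lies a 1.0-fold lower number from compound 1 to compound 2 (0.01 log units; within the scatter). Compound 3 `CC(=O)N1N=C(c2ccc3ccccc3c2)OC1c1ccccc1[N+](=O)[O-]`, at 18.2 ug/mL, has the highest number of the three, which makes it the weakest inhibitor so far. Compound 4 `CC(=O)N1N=C(c2ccc3ccccc3c2)OC1c1cccnc1` is not yet measured. It carries pyridin-3-yl in place of 2-nitrophenyl on a saturated ring carbon. The closest evidence is two modest steps, a 7.5-fold higher number from compound 1 to compound 3 (0.87 log units; beyond the scatter) and a 7.7-fold higher number from compound 2 to compound 3 (0.89 log units; beyond the scatter), which set the nitro compound apart. Among the measured compounds shown here, no measured compound carries pyridin-3-yl, so only a partial return towards the other two is expected. The expected change is a 3.6-fold lower number from compound 3 to compound 4 (0.56 log units; beyond the scatter), towards stronger inhibition. For compound 4 the estimate is 5 ug/mL, with an expected range of 1.5 ug/mL to 16 ug/mL.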

Compound 4, half-maximal inhibitory concentration: 2.61 ug/mL
For compound 4 the middle estimate is 1.9-fold (0.28 log units) above the measured one; the measured number falls inside the stated range.
By their numbers in this assay, from the lowest: compounds 2, 1 and 4 (each within the scatter of the next); then compound 3.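

Replacing 2-nitrophenyl with pyridin-3-yl on the saturated ring carbon gives stronger inhibition in this assay (a 7.0-fold lower number from compound 3 to compound 4 (0.84 log units; beyond the scatter)). Pyridin-3-yl cannot be told apart from 2-chlorophenyl (a 1.1-fold higher number from compound 2 to compound 4 (0.04 log units; within the scatter)) or phenyl (a 1.1-fold higher number from compound 1 to compound 4 (0.03 log units; within the scatter)), so a ring nitrogen in this aromatic ring leaves the read-out within the scatter, and among these four compounds only 2-nitrophenyl stands apart. Nothing measured here explains that difference. Still open, going by these compounds, is how an amine or a carboxylic acid on the phenyl ring would read, and whether a non-aromatic ring such as piperidine would match pyridin-3-yl.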